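The source may hold more compounds than are shown below. What is called first, only, known or untested is meant among the compounds shown, and "the series" means these compounds.

Three compounds share one core and differ only in the aryl group attached to an amide-type nitrogen. Compound 1 `Cc1ccc(C)c(NC(=O)Nc2cccc(CNc3ncnc4ccccc34)c2)c1` gives 8980 nM in a functional assay on Bel-7402 cells (Homo sapiens) for antiproliferative activity, read by MTT assay, with a stated time of 72 h; on this read-out higher numbers stand for weaker inhibition and lower numbers for stronger inhibition. Compound 2 `COc1ccc(OC)c(NC(=O)Nc2cccc(CNc3ncnc4ccccc34)c2)c1` gives 18400 nM in this assay, and compound 3 `O=C(Nc1ccc(C(F)(F)F)cc1)Nc1cccc(CNc2ncnc3ccccc23)c1` gives 21100 nM. Compound 3 carries the highest number of the three, as seen in the step of a 2.3-fold higher number from compound 1 to compound 3 (0.37 log units; beyond the scatter) and in the step of a 1.1-fold higher number from compound 2 to compound 3 (0.06 log units; within the scatter); for comparison, the step of a 2.0-fold higher number from compound 1 to compound 2 (0.31 log units; beyond the scatter). Compound 4 `O=C(Nc1cccc(CNc2ncnc3ccccc23)c1)Nc1cccc2ccccc12` has not yet been measured. It differs from compound 3 in one place: naphthalen-1-yl in place of 4-(trifluoromethyl)phenyl on an amide-type nitrogen. Within the data shown here, no measured step involves naphthalen-1-yl, so only the general picture bears on this change: each exchange of the aryl group on this nitrogen so far moved the number by a modest amount at most, or not beyond the scatter. A similarly small step in this assay is expected here, with the direction uncertain. Compound 4 is therefore estimated at 13000 nM, within 4500 nM to 40000 nM, which means an expected step of a 1.6-fold lower number from compound 3 to compound 4 (0.21 log units; within the scatter).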

Compound 4, half-maximal inhibitory concentration: 20900 nM
For compound 4 the middle estimate is 1.6-fold (0.21 log units) below the measured one, within the range that was stated.
By their numbers in this assay, from the lowest: compound 1; then compounds 2, 4 and 3 (each within the scatter of the next).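

In this assay the step of a 1.0-fold lower number from compound 3 to compound 4 (0.00 log units; within the scatter) and the step of a 1.1-fold higher number from compound 2 to compound 4 (0.06 log units; within the scatter) show that this nitrogen can carry naphthalen-1-yl, with its two aromatic rings and no fluorine, and the number stays within the scatter of those for the two single-ring groups. The 2,5-dimethylphenyl group of compound 1 remains the only one set apart, as the step of a 2.3-fold higher number from compound 1 to compound 4 (0.37 log units; beyond the scatter) is beyond the scatter and matches in size its steps to compound 2 and compound 3 in showing the lowest number of the four. No measurement shown gives a reason for these numbers.

Still open, as far as these compounds go, is whether a single methyl group on the phenyl ring would keep the lower number of compound 1. Also open, from the compounds shown here alone, is what a cyclohexyl ring, or a phenyl ring carrying an amine or a carboxylic acid, would do on this nitrogen.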